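Removing a para hydroxy from a stilbene core

The source may report more compounds than this note shows. Statements on the series, on what has been measured and on what is new or still open speak of the compounds shown alone.

Compound 1 `CC(C)(O)C(O)Cc1c(O)cc(/C=C/c2ccc(O)cc2)cc1O` gives 1.59 in a physicochemical assay for lipophilicity, read by HPLC, measured as octanol-water partition (on this read-out higher numbers stand for higher lipophilicity and lower numbers for lower lipophilicity), and compound 2 `CC(C)(O)C(O)Cc1c(O)cc(/C=C/c2ccccc2)cc1O` gives 2.59. The change between them, (hydrogen in place of hydroxy on an aromatic carbon), made a step of a number 1.00 log units higher from compound 1 to compound 2 (beyond the scatter). Compound 3 `Oc1ccc(/C=C/c2cccc(O)c2)cc1` gives 2.08 in this assay, standing between compound 1 and compound 2; the difference between the core of compound 3 and that of compound 1 is not broken down here. Compound 4 `Oc1cccc(/C=C/c2ccccc2)c1` has not been measured. It differs from compound 3 by hydrogen in place of hydroxy on an aromatic carbon, the same kind of change as from compound 1 to compound 2, except that the place is para to a group of 9 heavy atoms rather than para to a large group. Compound 4 is expected to show a step of about a number 1.00 log units higher from compound 3 to compound 4 (beyond the scatter), because the same change gave a number 1.00 log units higher from compound 1 to compound 2 (beyond the scatter). Compound 4 is thus estimated at 3.08, within 2.7 to 3.5.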

Compound 4, partition coefficient: 3.22
Estimate against measurement, compound 4: 0.14 log units below; the range from low to high includes it.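

In this assay, hydrogen in place of hydroxy on an aromatic carbon gave a number 1.14 log units higher from compound 3 to compound 4 (beyond the scatter) and, on the other core, a number 1.00 log units higher from compound 1 to compound 2 (beyond the scatter) as well, so the change went in the same direction on both cores and beyond the scatter each time. Two pairs show only that it carried over between these two cores; they do not show that it would do so on any other core or at any other place on the ring. Nothing at hand accounts for the size of either step.

Left open is how an amine or a carboxylic acid in place of the hydroxy would read in this assay. Also open, as far as these compounds go, is whether the step would hold on a core carrying a longer chain.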